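The compounds below may be only part of what the source reports. "The series", "measured", "known", "first", "only" and "open" are said of these compounds alone.

Compound 1 `COc1ccc2[nH]c(C(=O)N3CC(=O)N(Cc4ccccc4)[C@@H](CCc4ccccc4)C3)cc2c1` is tolerated in an ADME assay on Vero cells (Chlorocebus sabaeus) for cytotoxicity, with a stated time of 7 days (a lower number here means that less compound is tolerated, a higher number that more compound is tolerated), only to a limit: compound 1 gives > 30000 nM, a limit of the assay rather than a number. Compound 2 `COc1ccc2[nH]c(C(=O)N3CC(=O)N(Cc4ccccc4)[C@@H](COc4ccccc4)C3)cc2c1` likewise gives only a limit, > 10000 nM. The step that the two limits leave unreadable from compound 1 to compound 2 therefore cannot be read, since both values sit at limits the limit of > 10000 nM in this assay, at which 1 of the 2 values shown sits (the limit of > 30000 nM in this assay, at which 1 of the 2 values shown sits). Compound 3 `COc1ccc2[nH]c(C(=O)N3CC(=O)N(Cc4ccccc4)[C@@H](CN4CCC(C)CC4)C3)cc2c1` differs from compound 1 by 4-methylpiperidin-1-yl in place of benzyl on a saturated chain carbon bound to a saturated ring carbon. Among the measured compounds shown here, no measured step bears on this change. Compound 3 is expected to stay at the limit, with a step of a number no higher from compound 1 to compound 3 (the limit leaves the size open) that is not readable beyond the scatter. The estimate for compound 3 is 30000 nM, between 10000 nM and 80000 nM.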

Compound 3, half-maximal cytotoxic concentration: > 30000 nM
Compound 3 was reported as a limit; the forecaster's own chance of this, stated with the estimate: 70%; the middle value lies on the limit itself.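

Compound 3 gives > 30000 nM, a limit of the assay, and its steps from compound 1 and compound 2 cannot be read: the limit of > 30000 nM in this assay, at which 2 of the 3 values shown sit.

From the compounds shown here alone, whether benzyl, phenoxy or 4-methylpiperidin-1-yl at this place changes the result in this assay stays open.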